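The compounds below may be only part of what the source reports. "The series", "measured", "known", "first", "only" and "open" are said of these compounds alone.

Three compounds that share one core and differ only in the group on the triple-bonded carbon have been measured in a functional assay on BaF3 cells (Mus musculus) for antiproliferative activity; a lower number here means that less compound is needed, a higher number that more compound is needed for the effect. Compound 1 (`CCN1CCN(Cc2ccc(NC(=O)c3ccc(C)c(C#Cc4ccc(C(=O)NC)nc4)c3)cc2C(F)(F)F)CC1`) gives 3980 nM, compound 2 (`CCN1CCN(Cc2ccc(NC(=O)c3ccc(C)c(C#Cc4cncnc4)c3)cc2C(F)(F)F)CC1`) gives 2190 nM, and compound 3 (`CCN1CCN(Cc2ccc(NC(=O)c3ccc(C)c(C#Cc4cnccn4)c3)cc2C(F)(F)F)CC1`) gives 2490 nM. Compound 3 therefore stands within the scatter of both of the others.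

Among the measured compounds shown here, compound 4 (`CCN1CCN(Cc2ccc(NC(=O)c3ccc(C)c(C#Cc4cnc5[nH]cnc5c4)c3)cc2C(F)(F)F)CC1`) keeps the core of compound 3 and changes only this group: a group of 9 heavy atoms (6 carbon, 3 nitrogen; one five-membered aromatic ring with 2 hetero atoms, one six-membered aromatic ring with 1 hetero atom) in place of a group of 6 heavy atoms (4 carbon, 2 nitrogen; one six-membered aromatic ring with 2 hetero atoms), on a triple-bonded carbon.

For the measured compounds named here, three measured steps bear on the change: a 1.8-fold lower number from compound 1 to compound 2 (0.26 log units; within the scatter), a 1.6-fold lower number from compound 1 to compound 3 (0.20 log units; within the scatter) and a 1.1-fold higher number from compound 2 to compound 3 (0.06 log units; within the scatter). So among these three compounds, no exchange at this place has moved the number beyond the scatter. None of the steps, however, brings in a group with a five-membered aromatic ring, so the data do not measure a change of this kind. The flat record argues against relying on any measured trend, and the range must stay wide.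

The expected move is a 3.1-fold lower number from compound 3 to compound 4 (0.49 log units; beyond the scatter), a tentative lean towards a lower number that rests on the size of the new group alone. Compound 4 is estimated at 800 nM, with an expected range from 100 nM to 3500 nM.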

Compound 4, half-maximal effective concentration: 60 nM
Compound 4: the middle estimate sits 13-fold (1.12 log units) above what was measured, outside the stated range (below it).
By their numbers in this assay, from the lowest: compound 4; then compounds 2, 3 and 1 (each within the scatter of the next).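

In this assay, this place on the triple-bonded carbon proves far from silent: the group with one five-membered and one six-membered aromatic ring gives a 42-fold lower number from compound 3 to compound 4 (1.62 log units; beyond the scatter), and likewise a 37-fold lower number from compound 2 to compound 4 (1.56 log units; beyond the scatter) and a 66-fold lower number from compound 1 to compound 4 (1.82 log units; beyond the scatter). Among the compounds shown here, all three steps lie beyond the scatter, whereas the earlier exchanges among groups with a single six-membered aromatic ring all stayed within it, so the flat record does not extend to this new group, and heavy-atom count alone does not sort the results, since the group leaving compound 1 is larger than the one entering and the step still runs towards a lower number. Nothing measured here accounts for a step of this size.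

The compounds shown do not separate the five-membered aromatic ring from the hydrogen-bond donor that enters with it, so neither feature can be credited on its own. Going by these compounds, whether the number stays this low with a methyl group on the nitrogen of the five-membered ring, or with an amine on the same group, remains open.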